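The compounds below may be only part of what the source reports. "The series", "measured", "known", "first", "only" and "open" are said of these compounds alone.

Measured so far in a functional assay on a cell-free system (plasma, Homo sapiens), with a stated time of 3 min; a lower number here means a stronger inhibitor, a higher number a weaker inhibitor:
compound 1 `O=C(NCc1cc(Cl)ccc1-n1cnnn1)[C@@H]1[C@@H]2C[C@@H]2CN1C(=O)[C@H](O)c1ccccc1F` gives 580 nM
compound 2 `O=C(NCc1cc(Cl)ccc1-n1cnnn1)[C@@H]1C[C@@H]2C[C@@H]2N1C(=O)[C@H](O)c1ccccc1F` gives 770 nM
compound 3 `O=C(NCc1cc(Cl)ccc1-n1cnnn1)[C@@H]1[C@@H]2C[C@@H]2CN1C(=O)[C@H](O)c1ccccc1` gives 700 nM

Compound 1 and compound 2 have the same atoms joined differently; the difference between the two cores is not broken down here. Their two numbers lie within the scatter of each other, and the same holds for compound 2 against compound 3, so no order among the three is read from these figures.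

Compound 3 is obtained from compound 1 by hydrogen in place of fluoro on an aromatic carbon. That change gave a 1.2-fold higher number from compound 1 to compound 3 (0.08 log units; within the scatter).

Compound 4 `O=C(NCc1cc(Cl)ccc1-n1cnnn1)[C@@H]1C[C@@H]2C[C@@H]2N1C(=O)[C@H](O)c1ccccc1` has not yet been measured in this assay. Going by the values given here, it is obtained from compound 2 by hydrogen in place of fluoro on an aromatic carbon, the same change as the one from compound 1 to compound 3, at the same kind of place: on an aromatic carbon of a six-membered aromatic ring of carbon only, ortho to a large group.

For this assay the step is expected to be a 1.2-fold higher number from compound 2 to compound 4 (0.07 log units; within the scatter). Among the compounds with values here, that expectation rests on the single earlier instance, a 1.2-fold higher number from compound 1 to compound 3 (0.08 log units; within the scatter), which stayed within the scatter; with one instance only, the range is kept wide. Compound 4 is therefore estimated at 900 nM, expected between 500 nM and 1700 nM.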

Compound 4, half-maximal inhibitory concentration: 620 nM
Compound 4: the middle estimate sits 1.5-fold (0.16 log units) above what was measured; the measured number falls inside the stated range.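

In this assay, hydrogen in place of fluoro on the core of compound 2, the change from 2-fluorophenyl to phenyl, gave a 1.2-fold lower number from compound 2 to compound 4 (0.09 log units; within the scatter). Set beside the same change on the core of compound 1, the two steps cannot be told apart: the same change on two cores in this assay, a 1.2-fold higher number (0.08 log units; within the scatter) from compound 1 to compound 3 and a 1.2-fold lower number (0.09 log units; within the scatter) from compound 2 to compound 4, 1.5-fold (0.18 log units) apart, within the scatter of two such steps. The change can therefore be carried between these two cores without a step beyond the scatter, but these two small steps establish neither a consistent direction nor any dependence on the core, and they say nothing about other cores.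

The compounds shown leave open whether a group other than fluoro or hydrogen at this place, such as methoxy or trifluoromethyl, would give a step beyond the scatter on either core. Also open, on these data alone, is whether an amine in place of the hydroxyl would behave alike on the two cores.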